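Swapping an aminophenyl ketone for a dichlorophenyl ketone

A few compounds are considered here, and "the series" means these few. Any claim that something is new, unique, unknown or untested is made for them only; others in the source may bear on it.

Compound 1 `COc1cc(-c2cc(/C=C/C(=O)c3ccc(N)cc3)[nH]n2)cc(OC)c1OC` carries a 4-aminophenyl on its carbonyl carbon, and compound 2 `COc1ccc(-c2cc(/C=C/C(=O)c3ccc(OC)c(OC)c3)[nH]n2)cc1` is a related compound tested alongside it. In a functional assay on SW-620 cells (Homo sapiens) for cytotoxicity, read by sulforhodamine B assay, with a stated time of 48 h, tested at 0.01 uM (on this read-out higher numbers stand for a weaker effect at the one concentration tested and lower numbers for a stronger effect), compound 1 gives 95%, and in this assay compound 2 gives 99%. Of these two numbers compound 1 supplies the smaller, but the difference from compound 2 lies within the scatter, so the two cannot be told apart and both show only a weak effect at the concentration tested.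

Compound 3 `COc1cc(-c2cc(/C=C/C(=O)c3ccc(Cl)c(Cl)c3)[nH]n2)cc(OC)c1OC` has not yet been measured. It differs from compound 1 in one place: 3,4-dichlorophenyl in place of 4-aminophenyl on a carbonyl carbon. Within the data shown here, no measured pair in this set differs by this change alone, so its effect cannot be read from the numbers. Among the measured compounds shown here, both measured compounds sit close to the top of the scale, leaving little room for a weaker effect, and the single exchange gives no ground to expect a stronger one. The step from compound 1 to compound 3 is therefore expected to be a number 2 percentage points higher from compound 1 to compound 3 (within the scatter), within the scatter. Compound 3 is estimated to give 97% in this assay, with a likely range from 85% to 105%.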

Compound 3, a percentage reported as activity, at one concentration (the size of the read-out at that concentration, not a potency): 98%
Estimate against measurement, compound 3: 1 percentage points below, and the stated range covers the measured number.
By their numbers in this assay, from the lowest: compounds 1, 3 and 2 (each within the scatter of the next).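

Among these compounds, the exchange of 4-aminophenyl for 3,4-dichlorophenyl on a carbonyl carbon gives a first direct reading at this position: in this assay it appears as a number 3 percentage points higher from compound 1 to compound 3 (within the scatter) and so leaves the two compounds indistinguishable. The exchange replaces a group with one hydrogen-bond donor and one acceptor by a group with neither, and adds two chlorine atoms, yet at this one concentration the read-out does not separate them. No measurement available here explains why the two groups read alike.

The pair tells little about how far this position tolerates change, since a single exchange that leaves both compounds with only a weak effect at the concentration tested cannot show whether the position matters at all. On these data alone, it remains open whether a carboxylic acid, a nitrile or a longer chain ending in an amine in place of 4-aminophenyl on the carbonyl carbon would give a stronger effect, and whether the two compounds would separate at higher concentrations.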